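A few compounds are considered here, and "the series" means these few. Any claim that something is new, unique, unknown or untested is made for them only; others in the source may bear on it.

Compound 1 `CC1=CC(=O)/C(=C(/C)Nc2ccc3cnn(C)c3c2)C(=O)O1` and compound 3 `CC1=CC(=O)/C(=C(/C)Nc2ccc3c(cnn3C)c2)C(=O)O1` are built from the same atoms joined differently; the difference between the two cores is not broken down here. In an ADME assay on RAW264.7 cells (Mus musculus) for cytotoxicity, read by resazurin assay, with a stated time of 48 h (on this read-out higher numbers stand for lower toxicity in this test and lower numbers for higher toxicity in this test), compound 1 gives > 100000 nM, which is a limit of the assay rather than a number. Compound 3 likewise gives only a limit, > 100000 nM. Compound 2 `CCn1ncc2ccc(N/C(C)=C3\C(=O)C=C(C)OC3=O)cc21` differs from compound 1 by methyl in place of hydrogen on a saturated chain carbon bound to an aromatic nitrogen. In this assay compound 2 gives > 100000 nM, again a limit. The step that the two limits leave unreadable from compound 1 to compound 2 therefore cannot be sized, since both ends sit at the limit of > 100000 nM in this assay, at which 3 of the 3 values shown sit. Compound 4 `CCn1ncc2cc(N/C(C)=C3\C(=O)C=C(C)OC3=O)ccc21` stands to compound 3 as compound 2 stands to compound 1, differing by methyl in place of hydrogen on a saturated chain carbon bound to an aromatic nitrogen, the same change on the same kind of carbon. All three measured values rest on (the limit of > 100000 nM in this assay, at which 3 of the 3 values shown sit), so nothing in this set shows toxicity within the measurable range for either core or for this change. The step that the limit leaves unreadable from compound 3 to compound 4 is expected to be flat, because a step that the two limits leave unreadable from compound 1 to compound 2 was unreadable for the same change. For compound 4 the expected value is 150000 nM, within an estimated range from 60000 nM to 400000 nM, most likely reported once more only as a limit.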

Compound 4, half-maximal cytotoxic concentration: > 100000 nM
Compound 4: only a limit was reported; the forecaster's own chance of this, stated with the estimate: 85%; the middle value does not contradict the limit.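

Compound 4 gives > 100000 nM in this assay, again a limit of the assay and not a number. Compound 3 also ended at a limit, so no size can be read for the step between compound 3 and compound 4: the limit of > 100000 nM in this assay, at which 4 of the 4 values shown sit.

The compounds shown leave open how toxic any of them is in this assay, and whether swapping hydrogen for methyl or changing the core alters that toxicity at all.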